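Cyano in place of fluoro: an expected clearance

A few compounds are considered here, and "the series" means these few. Any claim that something is new, unique, unknown or untested is made for them only; others in the source may bear on it.

Measured in an in vitro ADME assay on microsomes from liver (Mus musculus) for pharmacokinetics, read by LC-MS; on this read-out higher numbers stand for fast clearance and lower numbers for slow clearance:
Compound 1 `Cc1nc2ccc(C(F)(F)F)cc2n1-c1ccc(C(=O)NC2CC2)s1`: 68 mL/min/kg
Compound 2 `Cc1nc2c(F)cccc2n1-c1ccc(C(=O)NC2CC2)s1`: 37 mL/min/kg
Compound 3 `Cc1nc2ccc(F)cc2n1-c1ccc(C(=O)NC2CC2)s1`: > 72 mL/min/kg, a limit of the assay

Compound 2 gives 37 mL/min/kg and compound 1 gives 68 mL/min/kg, two values within the scatter of each other. Compound 4 `Cc1nc2c(C#N)cccc2n1-c1ccc(C(=O)NC2CC2)s1` differs from compound 2 by cyano in place of fluoro on an aromatic carbon, which is cyano in place of fluoro on an aromatic carbon. Within the data shown here, the one measured step that bears on this is an at least 1.0-fold higher number from compound 1 to compound 3 (0.02 log units; that floor lies within the scatter), a different exchange whose floor lies within the scatter, so no step beyond the scatter is expected in this assay. The estimated step is a 1.1-fold higher number from compound 2 to compound 4 (0.03 log units; within the scatter). For compound 4 the estimated value is 40 mL/min/kg, with an expected range from 20 mL/min/kg to 70 mL/min/kg.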

Compound 4, clearance: 26 mL/min/kg
Estimate against measurement, compound 4: 1.5-fold (0.19 log units) above, and the stated range covers the measured number.
By their numbers in this assay, from the lowest: compounds 4, 2 and 1 (each within the scatter of the next, the first and the last beyond it). At a limit, above all of these: compound 3.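

In this assay, cyano in place of fluoro on this aromatic carbon, ortho to a fused ring, gives a 1.4-fold lower number from compound 2 to compound 4 (0.15 log units; within the scatter). This is the first exchange shown at this position, and the two groups, though they differ in size and in hydrogen-bond acceptors, give values within the scatter of each other. Nothing measured here gives a cause for this small step. Going by these compounds, whether an amine or a carboxylic acid at this position would also stay within the scatter of compound 2 remains open. So does the effect of cyano in place of the fluoro of compound 3.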